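Pyrrolidine amide cap variation: tert-butyl ketone to urea

A few compounds are considered here, and "the series" means these few. Any claim that something is new, unique, unknown or untested is made for them only; others in the source may bear on it.

Compound 1 `CC(C)(C)OC(=O)N1C(=O)CC[C@H]1C(=O)N1CCC(NS(=O)(=O)c2cc(S(=O)(=O)c3ccccc3)ccc2C(F)(F)F)CC1` and compound 2 `CC(C)(C)C(=O)N1CCC[C@H]1C(=O)N1CCC(NS(=O)(=O)c2cc(S(=O)(=O)c3ccccc3)ccc2C(F)(F)F)CC1` share one core and differ in the cap on the pyrrolidine nitrogen. In a functional assay on U2OS cells for antagonist activity at proto-oncogene Wnt-3 (Homo sapiens), read by a luciferase reporter, with a stated time of 18 h (a higher number here means that more compound is needed for the effect, a lower number that less compound is needed), compound 1 gives 90 nM, and in this assay compound 2 gives 270 nM, the higher of the two numbers and beyond the scatter. Compound 3 `CN(C)C(=O)N1CCC[C@H]1C(=O)N1CCC(NS(=O)(=O)c2cc(S(=O)(=O)c3ccccc3)ccc2C(F)(F)F)CC1` carries dimethylamino in place of tert-butyl on a carbonyl carbon. Within the data shown here, no measured pair shows this change, so the step is expected to be small or none beyond the scatter: a 1.4-fold lower number from compound 2 to compound 3 (0.13 log units; within the scatter) is the expected step. Compound 3 is therefore estimated at 200 nM, within 70 nM to 600 nM.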

Compound 3, half-maximal effective concentration: 160 nM
Beside the measured number, compound 3's estimate is 1.3-fold (0.10 log units) above it; the measured number falls inside the stated range.
By their numbers in this assay, from the lowest: compounds 1, 3 and 2 (each within the scatter of the next, the first and the last beyond it).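

In this assay, among these compounds, the exchange of tert-butyl for dimethylamino on a carbonyl carbon is a 1.7-fold lower number from compound 2 to compound 3 (0.23 log units; within the scatter) and so gives the first measured step at this position. On this pair, a cap with nitrogen on the carbonyl carbon and an all-carbon cap cannot be told apart. Nothing available explains this result. The compounds shown leave open how a ring on that carbonyl carbon, such as piperidine or morpholine, would read. They also leave open a longer chain ending in an amine or a carboxylic acid.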